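Trading Ethyl for Trifluoromethyl on a Shared Core

The source may report more compounds than this note shows. Statements on the series, on what has been measured and on what is new or still open speak of the compounds shown alone.

Within the data shown here, in a physicochemical assay for acid dissociation, using potentiometric titration, compound 1 `CCc1cc(N2CC[C@@H](NC)C2)nc(N)n1` gives 7.5, the higher of the two numbers measured so far. Among the measured compounds shown here, the only other measured compound, compound 2 `CCc1cc(N2CC[C@@H](NC)C2)ncn1`, gives 5.9. Compound 3 `CN[C@@H]1CCN(c2cc(C(F)(F)F)nc(N)n2)C1` is still unmeasured. It keeps the core of compound 1 and changes one group: trifluoromethyl in place of ethyl on an aromatic carbon. For the measured compounds named here, no measured step covers this swap. The nearest guide is a number 1.60 log units lower from compound 1 to compound 2 (beyond the scatter), which shows that one change on the aromatic ring can move this number well beyond the scatter. That step sits at another place on the ring, so it serves only as a yardstick of size. In this assay, the expected step is a number 3.00 log units lower from compound 1 to compound 3 (beyond the scatter), a downward move estimated to be larger than the measured one. For compound 3, the estimated value is 4.5, with an expected range from 3.5 to 5.6.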

Compound 3, acid dissociation constant: 3.1
Estimate against measurement, compound 3: 1.40 log units above, and the stated range ends above it.
By their numbers in this assay, from the lowest: compound 3; then compound 2; then compound 1.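

In this assay, the group on this aromatic carbon proves to be a strong lever: trifluoromethyl in place of ethyl gives a number 4.40 log units lower from compound 1 to compound 3 (beyond the scatter). This step is larger than a number 1.60 log units lower from compound 1 to compound 2 (beyond the scatter), the earlier change of amino to hydrogen at another place on the ring, so among these compounds the largest shift comes from this position. No measurement at hand explains why the number falls so far.

With only ethyl and trifluoromethyl shown on this carbon, it remains open where a methyl group, a chlorine atom or a nitrile there would place the number between these two results. Also open, on these data alone, is whether the same swap would move the number as far in compound 2, which carries hydrogen in place of the amino group.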